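The source may hold more compounds than are shown below. What is called first, only, known or untested is meant among the compounds shown, and "the series" means these compounds.

Measured compounds:
compound 1 `C#Cc1cn([C@@H]2O[C@H](CO)[C@@H](O)[C@H]2O)c2ncnc(NC)c12`, > 15000 nM
compound 2 `CNc1ncnc2c1c(I)cn2[C@@H]1O[C@H](CO)[C@@H](O)[C@H]1O`, > 20000 nM
compound 3 `C#Cc1cn([C@@H]2O[C@H](CO)[C@@H](O)[C@H]2O)c2ncnc(OC)c12`, 12700 nM

In a functional assay on HepG2 cells (Homo sapiens) for antiproliferative activity, read by XTT assay, with a stated time of 72 h (a higher number here means a weaker inhibitor, a lower number a stronger inhibitor), compound 1 gives only a limit, > 15000 nM. Compound 2 likewise gives only a limit, > 20000 nM. Within the data shown here, compound 3 is the one compound of the three with a number, giving 12700 nM in this assay.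

Compound 2 differs from compound 1 by iodo in place of ethynyl on an aromatic carbon. Because both values are limits, the limit of > 15000 nM in this assay, at which 1 of the 3 values shown sits, and (the limit of > 20000 nM in this assay, at which 1 of the 3 values shown sits), the step that the two limits leave unreadable from compound 1 to compound 2 cannot be read. Compound 3 differs from compound 1 by methoxy in place of methylamino on an aromatic carbon, and the step of an at least 1.1-fold lower number from compound 1 to compound 3 (0.07 log units; that floor lies within the scatter) is a floor that lies within the scatter of this kind of measurement.

Compound 4 `COc1ncnc2c1c(I)cn2[C@@H]1O[C@H](CO)[C@@H](O)[C@H]1O` has not been measured. It differs from compound 3 by iodo in place of ethynyl on an aromatic carbon, the same change that separates compound 1 from compound 2, made on the core of compound 3 rather than the core of compound 1. The earlier step of that change is unreadable, so it gives no size to carry over. What is known is that compound 3 sits close to the limits, and compound 4 is therefore expected to give a value near those limits in this assay, with an expected step of a 1.6-fold higher number from compound 3 to compound 4 (0.20 log units; within the scatter). The estimate for compound 4 is 20000 nM, expected to fall between 8000 nM and 50000 nM, with a fair chance that only a limit is reported.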

Compound 4, half-maximal inhibitory concentration: > 20000 nM
Compound 4: a limit, no number; the forecaster's own chance of this, stated with the estimate: 60%; the middle value sits exactly at the limit.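

Among these compounds, on the core of compound 3, iodo in place of ethynyl in this assay gives an at least 1.5-fold higher number from compound 3 to compound 4 (0.19 log units; that floor lies within the scatter), so the one readable step of this change is a floor and not a size. The same change on the core of compound 1, and the step from compound 2 to compound 4, cannot be read because both ends of each are limits, and the limit reached by compound 4 is shared with compound 2: the limit of > 20000 nM in this assay, at which 2 of the 4 values shown sit. Among the compounds shown here, the series therefore shows only that both iodo compounds give limits and no number, and it does not show whether the change has the same size on the two cores or any real size at all.

The compounds shown leave open what other groups on this aromatic carbon of the five-membered aromatic ring would give, such as bromo, an amine or a longer chain ending in a triple bond, in this assay. They also leave open whether replacing methoxy or methylamino with another group on the shared core, such as a plain amine or a carboxylic acid, would give a number clear of the limits.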